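Aryl-alkyne series: trifluoromethyl for hydroxy on compound 3

The source may report more compounds than this note shows. Statements on the series, on what has been measured and on what is new or still open speak of the compounds shown alone.

Compound 3 `OCCCCC#Cc1ccccc1C#Cc1cccc(O)c1` is compared against compound 1 `OCCCCC#Cc1ccccc1C#Cc1cccs1` and compound 2 `COc1cccc(C#Cc2ccccc2C#CCCCCO)c1`. In a functional assay on OVCAR-3 cells (Homo sapiens) for cytotoxicity (on this read-out lower numbers stand for stronger inhibition of growth and higher numbers for weaker inhibition of growth), compound 3 gives 20000 nM; compound 1 gives 15000 nM and compound 2 gives 10700 nM in this assay. Neither neighbour separates from compound 3: a 1.3-fold higher number from compound 1 to compound 3 (0.12 log units; within the scatter) and a 1.9-fold higher number from compound 2 to compound 3 (0.27 log units; within the scatter) both fall within the scatter, so the three numbers are effectively one level.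

Compound 4 `OCCCCC#Cc1ccccc1C#Cc1cccc(C(F)(F)F)c1` carries trifluoromethyl in place of hydroxy on an aromatic carbon. The step that bears most directly on it is the exchange at the same oxygen, a 1.9-fold higher number from compound 2 to compound 3 (0.27 log units; within the scatter), which did not move the number; the exchange of the whole aryl arm, a 1.3-fold higher number from compound 1 to compound 3 (0.12 log units; within the scatter), likewise stayed within the scatter. With only null steps available, no change beyond the scatter is expected in this assay for compound 4, and the estimated step is a 1.3-fold lower number from compound 3 to compound 4 (0.12 log units; within the scatter).

Compound 4 is therefore estimated at 15000 nM in this assay, with an expected range from 6000 nM to 40000 nM.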

Compound 4, concentration for 50% growth inhibition: 16800 nM
The estimate for compound 4 lay 1.1-fold (0.05 log units) below the measured number; the range from low to high includes it.
By their numbers in this assay, from the lowest: compounds 2, 1, 4 and 3 (each within the scatter of the next).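

In this assay, trifluoromethyl at this aromatic carbon, meta to a large group, gives a 1.2-fold lower number from compound 3 to compound 4 (0.08 log units; within the scatter), and in place of methoxy it gives a 1.6-fold higher number from compound 2 to compound 4 (0.20 log units; within the scatter). Until now, the position had been probed only by exchanging hydroxy and methoxy, both attached through oxygen; with trifluoromethyl, which is larger in heavy atoms and has no hydrogen-bond donor or acceptor, the number still stays within the scatter, so neither the oxygen nor the donor of hydroxy is needed to hold this level. No measurement on hand accounts for this flat response.

The compounds shown leave open whether any group at this carbon, such as an amine or a carboxylic acid, can separate from this level. Also open, on these data alone, is whether the number responds to changes elsewhere, such as a longer chain on the alcohol arm.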